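This account rests on a few compounds, and the source may have more. Where it says the series, first, only, none or still open, it means among the compounds named here.

Measured so far:
compound 1 `COc1cc2c(Oc3ccc(NC(=O)c4nn(-c5ccccc5)c(=O)c5ccccc45)cc3F)ccnc2cc1OCCCN1CCCC1` — 980 nM in a functional assay on HT-29 cells (Homo sapiens) for cytotoxicity, read by MTT assay, with a stated time of 72 h; on this read-out lower numbers stand for stronger inhibition and higher numbers for weaker inhibition
compound 2 `COc1cc2c(Oc3ccc(NC(=O)c4nn(-c5ccccc5)c(=O)c5ccccc45)cc3F)ccnc2cc1OCCCN1CCC(C)CC1` — 1040 nM in this assay

Compound 2 gives the nominally larger of the two numbers, yet a 1.1-fold higher number from compound 1 to compound 2 (0.03 log units; within the scatter) does not separate it from compound 1. Compound 3 `COc1cc2c(Oc3ccc(NC(=O)c4nn(-c5cccc(F)c5)c(=O)c5ccccc45)cc3F)ccnc2cc1OCCCN1CCC(C)CC1` differs from compound 2 by fluoro in place of hydrogen on an aromatic carbon. Within the data shown here, the one measured step, a 1.1-fold higher number from compound 1 to compound 2 (0.03 log units; within the scatter), changes the amine on the chain rather than the aromatic ring, so no step yet probes this position; it shows only that the series tolerates small changes without moving. Compound 3 is therefore expected to give 1000 nM (range 400 nM to 2500 nM), a step of a 1.0-fold lower number from compound 2 to compound 3 (0.02 log units; within the scatter) not beyond the scatter.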

Compound 3, half-maximal inhibitory concentration: 500 nM
Compound 3: the middle estimate sits 2.0-fold (0.30 log units) above what was measured, within the range that was stated.
By their numbers in this assay, from the lowest: compounds 3, 1 and 2 (each within the scatter of the next, the first and the last beyond it).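

In this assay, phenyl to 3-fluorophenyl gives a 2.1-fold lower number from compound 2 to compound 3 (0.32 log units; beyond the scatter), so this aromatic position responds to a single fluoro in place of hydrogen. The step is modest, but it is the only one of the two shown that lies beyond the scatter. Nothing available explains why this change moves the number.

From the compounds shown here alone, whether chloro or methoxy at this carbon would act in the same way remains open. So does whether the 3-fluorophenyl change holds with pyrrolidin-1-yl in place of 4-methylpiperidin-1-yl on the chain.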